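The source may report more compounds than this note shows. Statements on the series, on what has been measured and on what is new or still open speak of the compounds shown alone.

Measured so far in this series:
compound 1 `Nc1cccc2c(-c3cccc(NC(=O)c4ccc(Cl)cc4C(F)(F)F)c3)ccnc12` — > 20000 nM
compound 2 `Nc1cccc2c(-c3cccc(NC(=O)c4ccc(C(F)(F)F)cc4C(F)(F)F)c3)ccnc12` — > 20000 nM
compound 3 `CC(=O)Nc1cccc2c(-c3cccc(NC(=O)c4cc(Cl)cc(C(F)(F)F)c4)c3)ccnc12` — 6200 nM

In a functional assay on A375P cells (Homo sapiens) for antiproliferative activity, read by MTT assay, with a stated time of 48 h (a higher number here means a weaker inhibitor, a lower number a stronger inhibitor), compound 1 gives > 20000 nM, which is a limit of the assay and not a number. Compound 2 gives > 20000 nM, again a limit. The change trifluoromethyl in place of chloro on an aromatic carbon thus yields a step that the two limits leave unreadable from compound 1 to compound 2; both values sit at the limit of > 20000 nM in this assay, at which 2 of the 3 values shown sit, so no size can be read from this pair. For the measured compounds named here, compound 3 gives 6200 nM in this assay, the only number among the three. How the core of compound 3 differs from the core of compound 1 is not broken down here.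

Compound 4 `CC(=O)Nc1cccc2c(-c3cccc(NC(=O)c4cc(C(F)(F)F)cc(C(F)(F)F)c4)c3)ccnc12` remains to be measured. It differs from compound 3 by trifluoromethyl in place of chloro on an aromatic carbon, the same kind of change as from compound 1 to compound 2, though the place differs: in the first pair the carbon is para to a large group, in the second it is meta to a large group. Since the earlier step has no readable size, the expectation for compound 4 rests on compound 3 alone, which gives 6200 nM. The step is expected to be small, a 1.0-fold lower number from compound 3 to compound 4 (0.01 log units; within the scatter), within the usual scatter. Compound 4 is accordingly estimated at 6000 nM, between 2000 nM and 20000 nM.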

Compound 4, half-maximal inhibitory concentration: 1000 nM
For compound 4 the middle estimate is 6.0-fold (0.78 log units) above the measured one; the measured number lies below the stated range.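

In this assay, trifluoromethyl in place of chloro gives a 6.2-fold lower number from compound 3 to compound 4 (0.79 log units; beyond the scatter), so on the core of compound 3, at this place, the change has a readable effect. For the compounds shown here, the same kind of change on the core of compound 1 cannot be read, since compound 1 and compound 2 both stand at a limit of the assay and not at a number: the limit of > 20000 nM in this assay, at which 2 of the 4 values shown sit. Transfer of the change from one core to another is therefore neither supported nor contradicted, as only one readable step exists and the two pairs also differ in where the change sits on the ring.

Still open, going by these compounds, is whether a nitrile or a carboxylic acid in place of the entering trifluoromethyl group would keep compound 4 at 1000 nM or move it. Also open, on these data alone, is whether the step holds with a longer chain on the amide of the shared core.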